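Sulfonamide Piperidines at the Cytotoxicity Limit

The source may hold more compounds than are shown below. What is called first, only, known or untested is meant among the compounds shown, and "the series" means these compounds.

Compound 2 `Cc1cc(C)c(S(=O)(=O)N2CCC(N3CCCCC3)CC2)c(C)c1` carries a piperidin-1-yl group on a saturated ring carbon of its central ring. In an ADME assay on HCT-116 cells (Homo sapiens) for cytotoxicity, read by CellTiter-Glo, with a stated time of 72 h (a lower number here means a stronger inhibitor, a higher number a weaker inhibitor), compound 2 reaches only a limit of the assay, > 5000 nM, and not a number. Its nearest measured neighbour, compound 1 `Cc1cc(C)c(S(=O)(=O)N2CCC(N3CCC(C)OC3)CC2)c(C)c1`, likewise stops at a limit in this assay, > 5000 nM. Going by the values given here, the single comparison available, a step that the two limits leave unreadable from compound 1 to compound 2, is therefore unreadable, since the limit of > 5000 nM in this assay, at which 2 of the 2 values shown sit, covers both values. Compound 3 `CCCC(=O)NC1CCN(S(=O)(=O)c2c(C)cc(C)cc2C)CC1` has not yet been measured. It differs from compound 2 by (propylcarbonyl)amino in place of piperidin-1-yl on a saturated ring carbon. Among the compounds with values here, no measured step bears on this particular exchange, and the two limits offer no direction, so compound 3 is expected to stay at the limit as well rather than to move beyond the scatter. The estimate for compound 3 is 10000 nM, with a range from 3000 nM to 50000 nM, which would mean an expected step that the limit leaves unreadable from compound 2 to compound 3.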

Compound 3, half-maximal inhibitory concentration: > 5000 nM
Compound 3 gave a limit, no number; the forecaster's own chance of this, stated with the estimate: 85%; the middle value does not contradict the limit.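

No step to compound 3 can be read, either from compound 1 or from compound 2, since each of these compounds gives a limit and not a number: the limit of > 5000 nM in this assay, at which 3 of the 3 values shown sit. The compounds shown leave open which group on this saturated ring carbon, if any, would give a number in this assay.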